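The source may hold more compounds than are shown below. What is called first, only, known or untested is meant among the compounds shown, and "the series" means these compounds.

Compound 1 `CCCc1cn([C@H]2C[C@@H]3OP(=O)(O)OC[C@H]3O2)c(=O)[nH]c1=O` — in a functional assay on L1210 cells (Mus musculus) (a lower number here means a stronger inhibitor, a higher number a weaker inhibitor), it shows a limit of the assay, > 500 ug/mL
Compound 2 `CCCCc1cn([C@H]2C[C@H](O)[C@@H](CO)O2)c(=O)[nH]c1=O` — in this assay it also shows only a limit, > 500 ug/mL
Compound 3 `CCCCc1cn([C@H]2C[C@@H]3OP(=O)(O)OC[C@H]3O2)c(=O)[nH]c1=O` — not yet measured

Compound 1 stands at a limit and gives no real number in this assay. Compound 2 likewise stands at a limit. Both results sit at the limit of > 500 ug/mL in this assay, at which 2 of the 2 values shown sit, so neither compound shows measurable inhibition. Compound 3 differs from compound 1 by methyl in place of hydrogen on a saturated chain carbon, three bonds along the chain from an aromatic carbon. Among the compounds with values here, no measured step between compounds exists here, and with both known values at the limit, no step beyond the scatter is expected in this assay. The estimate for compound 3 in this assay is 500 ug/mL, ranging from 150 ug/mL to 2000 ug/mL. The expected step is a number no higher from compound 1 to compound 3 (the limit leaves the size open).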

Compound 3, concentration for 50% inhibition: 28.4 ug/mL
Estimate against measurement, compound 3: 18-fold (1.25 log units) above; measured number outside the range, below it.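

Methyl in place of hydrogen on the saturated chain carbon, which turns propyl into butyl, gives an at least 17-fold lower number from compound 1 to compound 3 (1.24 log units; beyond the scatter) in this assay, so this position responds strongly to a single added carbon. Compound 2 also carries a butyl chain, yet its result is only a limit, > 500 ug/mL. Butyl alone therefore does not guarantee a measurable number; it gives one on the core of compound 3.

From the compounds shown here alone, the exact size of the step stays open, since compound 1 sits at a limit: the limit of > 500 ug/mL in this assay, at which 2 of the 3 values shown sit. Whether a pentyl chain in place of butyl would lower the number further is also unknown.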